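Trading a Sulfonamide for a Bare Amine

The compounds below may be only part of what the source reports. "The series", "measured", "known", "first", "only" and "open" are said of these compounds alone.

Among the compounds with values here, compound 1, `CCS(=O)(=O)Nc1cccc2c1CCCC2c1c[nH]cn1`, is one of three compounds measured in a functional assay on Urethra for agonist activity at Alpha-1A adrenergic receptor (Oryctolagus cuniculus) (a higher number here means a more potent compound, by a factor of ten per unit of this negative logarithm, a lower number a less potent compound), where compound 1 gives 6.77. That places it second of the three. Compound 2, `CS(=O)(=O)Nc1c(O)ccc2c1CCCC2c1c[nH]cn1`, gives 7.77, a number beyond the usual scatter above compound 1, while compound 3, `CS(=O)(=O)Nc1ccc(F)c2c1CCCC2c1c[nH]cn1`, gives 5.31, well below it. The unmeasured compound 4, `Nc1cccc2c1CCCC2c1c[nH]cn1`, differs from compound 1 by one change: hydrogen in place of ethylsulfonyl on a nitrogen on an aromatic ring. Within the data shown here, no measured pair shows this exact change, so its effect must be judged from the shared core alone. Removing the whole sulfonyl group is expected to cost potency, with a step of a number 0.77 log units lower from compound 1 to compound 4 (beyond the scatter) in the downward direction. Compound 4 is therefore estimated at 6, within a range from 5.2 to 6.8.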

Compound 4, negative logarithm of the half-maximal effective concentration: 6.56
For compound 4 the middle estimate is 0.56 log units below the measured one, and the stated range covers the measured number.
By their numbers in this assay, from the lowest: compound 3; then compounds 4 and 1 (each within the scatter of the next); then compound 2.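

In this assay, (ethylsulfonyl)amino to amino gives a number 0.21 log units lower from compound 1 to compound 4 (within the scatter), so compound 1 and compound 4 cannot be told apart. At this nitrogen on an aromatic ring, then, the ethylsulfonyl group can be replaced by hydrogen without a change the assay can separate from scatter. No supporting measurement is available to explain this result.

Going by these compounds, it remains open whether an acetyl group or a longer chain such as butylsulfonyl on the same nitrogen would also leave the number within the scatter. It is also unknown whether the bare amine would keep this level if the core of compound 4 carried other groups.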